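From Fluoro to tert-Butyl: Notes on Compound 3

A few compounds are considered here, and "the series" means these few. Any claim that something is new, unique, unknown or untested is made for them only; others in the source may bear on it.

Measured so far in a functional assay (aorta) with Oryctolagus cuniculus as the target (a lower number here means tighter binding, a higher number weaker binding), for this series:
- compound 1 `COc1cc(C(C)O)ccc1OCCCN1CCC(C(c2ccc(F)cc2)c2ccc(F)cc2)CC1` reads 10 nM here
- compound 2 `Fc1ccc(OCCCN2CCC(C(c3ccc(F)cc3)c3ccc(F)cc3)CC2)cc1` reads 1.26 nM here

Compound 2 stands lowest of the two at 1.26 nM and serves as the reference point. Compound 3 `CC(C)(C)c1ccc(OCCCN2CCC(C(c3ccc(F)cc3)c3ccc(F)cc3)CC2)cc1` is still to be measured. It carries tert-butyl in place of fluoro on an aromatic carbon, para to a large group (tert-butyl in place of fluoro on an aromatic carbon).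

For the measured compounds named here, only one measured step bears on this, the exchange of the whole aromatic group on the same oxygen. That step is a 7.9-fold lower number from compound 1 to compound 2 (0.90 log units; beyond the scatter) and counts as modest. Read in reverse, compound 1, with the larger group, holds the higher number. Going by the values given here, this is a single comparison, and no measured compound carries tert-butyl, so the direction is only tentative. A small to modest rise in this assay is expected, no larger than the measured step. The expected change is a 2.4-fold higher number from compound 2 to compound 3 (0.38 log units; beyond the scatter) on this reading. Compound 3 is estimated at 3 nM with an expected range from 0.8 nM to 12 nM in this assay when measured.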

Compound 3, dissociation constant: 1 nM
Beside the measured number, compound 3's estimate is 3.0-fold (0.48 log units) above it; low and high end bracket the measured number.
By their numbers in this assay, from the lowest: compounds 3 and 2 (each within the scatter of the next); then compound 1.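

In this assay the aromatic carbon para to a large group accepts tert-butyl in place of fluoro, 4 heavy atoms for 1, with no change beyond the scatter: a 1.3-fold lower number from compound 2 to compound 3 (0.10 log units; within the scatter). Compound 3 therefore goes against the tentative link between a larger group and a higher number, and the heavy-atom count of this substituent does not track the reading across compound 2 and compound 3, while the exchange of the whole aromatic group remains a clear one, a 10-fold lower number from compound 1 to compound 3 (1.00 log units; beyond the scatter). No supporting data accompany this result, so it stands as an observation without an explanation.

Compound 1 differs from compound 2 and compound 3 by a whole 4-(1-hydroxyethyl)-2-methoxyphenyl group, so the compounds shown do not separate the contribution of the methoxy group from that of the 1-hydroxyethyl group. Also open is whether an amine or a carboxylic acid on the same aromatic carbon would read as compound 2 and compound 3 do, since fluoro and tert-butyl are the only single substituents shown there.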